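The source may hold more compounds than are shown below. What is called first, only, known or untested is meant among the compounds shown, and "the series" means these compounds.

Measured compounds:
- compound 1, `Cn1c(=O)c(=O)n(C2CCCC2)c2nc(N/N=C/c3ccccc3)ncc21`: > 100000 nM
- compound 2, `Cn1c(=O)c(=O)n(C2CCCC2)c2nc(N/N=C/c3ccc(S(C)(=O)=O)cc3)ncc21`: 86600 nM
- compound 3, `Cn1c(=O)c(=O)n(C2CCCC2)c2nc(N/N=C/c3ccc(F)cc3Br)ncc21`: 8390 nM

All three were tested in a functional assay on HCT-116 cells (Homo sapiens) for antiproliferative activity, read by MTT assay; a higher number here means a weaker inhibitor, a lower number a stronger inhibitor. For compound 1 the result is only a limit, > 100000 nM, not a measured number. That places compound 1 at the weak end of this small set, at the limit of > 100000 nM in this assay, at which 1 of the 3 values shown sits. Compound 2 gives 86600 nM, and the step is an at least 1.1-fold lower number from compound 1 to compound 2 (0.06 log units; that floor lies within the scatter). Compound 3 gives 8390 nM, which is an at least 11-fold lower number from compound 1 to compound 3 (1.07 log units; beyond the scatter) and also a 10-fold lower number from compound 2 to compound 3 (1.01 log units; beyond the scatter).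

Compound 4, `Cn1c(=O)c(=O)n(C2CCCC2)c2nc(N/N=C/c3ccc(F)cc3F)ncc21`, has not yet been measured. It differs from compound 1 in one place: 2,4-difluorophenyl in place of phenyl on a carbon with a double bond to nitrogen. The closest comparison is compound 3, where 2-bromo-4-fluorophenyl replaced phenyl and the result was an at least 11-fold lower number from compound 1 to compound 3 (1.07 log units; beyond the scatter); compound 4 carries fluorine in the place of that bromine. Because compound 3 moved an at least 11-fold lower number from compound 1 to compound 3 (1.07 log units; beyond the scatter), a downward step beyond the scatter is expected for compound 4 in this assay, an at least 5.0-fold lower number from compound 1 to compound 4 (0.69 log units; beyond the scatter), though its size is uncertain. Compound 4 is therefore estimated at 20000 nM, with a likely range from 6000 nM to 70000 nM.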

Compound 4, half-maximal inhibitory concentration: 19800 nM
For compound 4 the middle estimate is 1.0-fold (0.00 log units) above the measured one; measured number inside the range.
By their numbers in this assay, from the lowest: compound 3; then compound 4; then compound 2. At a limit, above all of these: compound 1.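

In this assay, the drop seen with compound 3 does not depend on bromine, since 2,4-difluorophenyl in place of phenyl gives an at least 5.0-fold lower number from compound 1 to compound 4 (0.70 log units; beyond the scatter). This step is only a floor, as compound 1 stands at a limit: the limit of > 100000 nM in this assay, at which 1 of the 4 values shown sits. The choice of halogen still counts, with fluoro in place of bromo giving a 2.4-fold higher number from compound 3 to compound 4 (0.37 log units; beyond the scatter), and the change of aromatic group from the methylsulfonyl compound gives a 4.4-fold lower number from compound 2 to compound 4 (0.64 log units; beyond the scatter).

The compounds shown leave open whether chloro or iodo on this ring would give a number nearer that of the bromo or the fluoro compound. They also leave open whether a hydroxyl, an amine or a carboxylic acid on the same ring would keep the number low, and they cannot tell why the halogen-bearing rings give lower numbers.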